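A few compounds are considered here, and "the series" means these few. Any claim that something is new, unique, unknown or untested is made for them only; others in the source may bear on it.

Measured compounds:
- compound 1, `O=C(CCCCCCc1nc2ccc(-c3ccccc3F)cc2[nH]1)NO`, 7400 nM in a functional assay on SK-OV-3 cells (Homo sapiens) for cytotoxicity; a lower number here means a stronger inhibitor, a higher number a weaker inhibitor
- compound 2, `COc1ccc(-c2ccc3nc(CCCCCCC(=O)NO)[nH]c3c2)cc1`, 3100 nM in this assay
- compound 3, `Cn1c(CCCCCCC(=O)NO)nc2ccccc21`, 3000 nM in this assay

The unmeasured compound is compound 4, `O=C(CCCCCCc1nc2ccccc2n1C1CCCC1)NO`. Among the three numbers, compound 3 has the lowest, but compound 2 stands within the scatter of it, so the two cannot be ordered; only compound 1 lies beyond the scatter, with the higher number. Within the data shown here, the one measured step, a 2.4-fold lower number from compound 1 to compound 2 (0.38 log units; beyond the scatter), concerns a change on an aromatic carbon of the shared core and gives a modest shift.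

Compound 4 differs from compound 3 as follows: cyclopentyl in place of methyl on an aromatic nitrogen. Among the measured compounds shown here, no measured pair shows a change on the aromatic nitrogen, so nothing in the data bears directly on this step. With only the modest step from compound 1 to compound 2 as a guide to how far the numbers move in this series, the expectation is that the step of a 1.2-fold lower number from compound 3 to compound 4 (0.08 log units; within the scatter) stays within the scatter. Compound 4 is therefore estimated at 2500 nM, with a range from 700 nM to 9000 nM that reflects the lack of a precedent.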

Compound 4, half-maximal inhibitory concentration: 4800 nM
The estimate for compound 4 lay 1.9-fold (0.28 log units) below the measured number; low and high end bracket the measured number.
By their numbers in this assay, from the lowest: compounds 3, 2, 4 and 1 (each within the scatter of the next, the first and the last beyond it).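

Among these compounds, on the aromatic nitrogen, a position that no earlier pair had varied, cyclopentyl in place of methyl gives a 1.6-fold higher number from compound 3 to compound 4 (0.20 log units; within the scatter) in this assay. Among the compounds shown here, the step replaces a single carbon with five heavy atoms and a five-membered non-aromatic ring, yet it stays within the scatter, so this position accepts at least this larger carbon ring without a measurable shift in the number, something the earlier compounds could not show. No measurement at hand offers an explanation for this result.

On these data alone, it remains open whether a benzyl group, a group carrying an amine or a carboxylic acid, or a longer alkyl chain on the aromatic nitrogen would also stay within the scatter. Also unresolved is how cyclopentyl on this nitrogen would combine with a 4-methoxyphenyl or 2-fluorophenyl group on the aromatic carbon of the shared core.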